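The compounds below may be only part of what the source reports. "The series", "measured", "known", "first", "only" and "open" are said of these compounds alone.

Series notes on the group at an aromatic carbon of the shared core. Compound 1 `CCc1nnn(Cc2ccc(C(F)(F)F)cc2)c1C(=O)N[C@@H](C)c1ccc(C(=O)O)cc1` carries an ethyl there. In a functional assay on CHO cells for antagonist activity at prostaglandin E2 receptor EP4 subtype (Homo sapiens), read by calcium flux, with a stated time of 15 min (on this read-out higher numbers stand for weaker inhibition and lower numbers for stronger inhibition), compound 1 returns only a limit, > 10000 nM; this is the limit of > 10000 nM in this assay, at which 1 of the 3 values shown sits. Compound 2 `C[C@H](NC(=O)c1c(C2CC2)nnn1Cc1ccc(C(F)(F)F)cc1)c1ccc(C(=O)O)cc1`, cyclopropyl in place of ethyl, gives 52.1 nM in this assay, a step of an at least 190-fold lower number from compound 1 to compound 2 (2.28 log units; beyond the scatter). Compound 3 `C[C@H](NC(=O)c1c(C2=CCOCC2)nnn1Cc1ccc(C(F)(F)F)cc1)c1ccc(C(=O)O)cc1` gives 119 nM in this assay, a step of an at least 84-fold lower number from compound 1 to compound 3 (1.92 log units; beyond the scatter) from the ethyl parent; among the two measured numbers compound 3 stands highest, the nearest step being a 2.3-fold higher number from compound 2 to compound 3 (0.36 log units; beyond the scatter).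

Compound 4 `Cc1ccc(-c2nnn(Cc3ccc(C(F)(F)F)cc3)c2C(=O)N[C@@H](C)c2ccc(C(=O)O)cc2)s1` differs from compound 3 by a group of 6 heavy atoms (5 carbon, 1 sulfur; one five-membered aromatic ring with 1 hetero atom) in place of a group of 6 heavy atoms (5 carbon, 1 oxygen; one six-membered non-aromatic ring with 1 hetero atom), on an aromatic carbon. The measured steps that bear on this are the large drops from ethyl to either ring, an at least 190-fold lower number from compound 1 to compound 2 (2.28 log units; beyond the scatter) and an at least 84-fold lower number from compound 1 to compound 3 (1.92 log units; beyond the scatter), which show that ring groups at this position are well accepted, and the modest rise of a 2.3-fold higher number from compound 2 to compound 3 (0.36 log units; beyond the scatter) on going from the three-membered to the six-membered ring. A ring of equal atom count, now aromatic, is therefore expected to land close to compound 3 in this assay, with at most a modest step and no firm direction. In this assay compound 4 is estimated at 70 nM, between 18 nM and 280 nM. The step thus expected is a 1.7-fold lower number from compound 3 to compound 4 (0.23 log units; within the scatter).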

Compound 4, half-maximal inhibitory concentration: 4.6 nM
The estimate for compound 4 lay 15-fold (1.18 log units) above the measured number, outside the stated range (below it).
By their numbers in this assay, from the lowest: compound 4; then compound 2; then compound 3. At a limit, above all of these: compound 1.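

Compound 4 shows that the heavy-atom count of the group does not set the number at this position in this assay: with that count equal on both sides, 5-methylthiophen-2-yl replacing the six-membered non-aromatic ring gives a 26-fold lower number from compound 3 to compound 4 (1.41 log units; beyond the scatter), and the same group also goes clearly past cyclopropyl, with an 11-fold lower number from compound 2 to compound 4 (1.05 log units; beyond the scatter). Among these compounds, the earlier compounds showed only that ring groups were far better than ethyl, with cyclopropyl and the six-membered ring a modest step apart; the aromatic ring now opens a larger gap among the ring groups themselves, and against ethyl the step widens to an at least 2100-fold lower number from compound 1 to compound 4 (3.33 log units; beyond the scatter). That last step has only a bound on one side, as compound 1 gives a limit and not a number: the limit of > 10000 nM in this assay, at which 1 of the 4 values shown sits.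

On these data alone, the new group brings an aromatic ring, a sulfur atom and a methyl together, so the share of each in the step remains open. Whether plain thiophen-2-yl, phenyl or a pyridine ring at this carbon would hold the number of compound 4, and whether a methoxy or a chlorine could stand in for the methyl, remains to be seen.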